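Swapping the Halogen on the Phenyl Ring: Compound 4

This account rests on a few compounds, and the source may have more. Where it says the series, first, only, none or still open, it means among the compounds named here.

Three compounds that share one core have been measured in a functional assay on A549 cells (Homo sapiens) for antiproliferative activity, read by MTT assay, with a stated time of 48 h; on this read-out lower numbers stand for stronger inhibition and higher numbers for weaker inhibition:

Compound 1, `Cc1cccn2cc(-c3nnc(-c4ccccc4)o3)nc12`, gives 23400 nM
Compound 2, `Cc1cccn2cc(-c3nnc(-c4ccc(Br)cc4)o3)nc12`, gives 34700 nM
Compound 3, `COc1ccc(-c2nnc(-c3cn4cccc(C)c4n3)o2)cc1`, gives 12800 nM

Among these three, compound 2 gives the highest number. Its gap to compound 1 is small, a 1.5-fold higher number from compound 1 to compound 2 (0.17 log units; within the scatter), and only its gap to compound 3 lies beyond the scatter, a 2.7-fold lower number from compound 2 to compound 3 (0.43 log units; beyond the scatter).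

Compound 4, `Cc1cccn2cc(-c3nnc(-c4ccccc4I)o3)nc12`, has not yet been measured. It differs from compound 2 in one place: 2-iodophenyl in place of 4-bromophenyl on an aromatic carbon.

Going by the values given here, two measured steps touch on the same phenyl ring. Putting bromo in place of hydrogen there changed little, a 1.5-fold higher number from compound 1 to compound 2 (0.17 log units; within the scatter), and putting methoxy in place of bromo gave a modest lowering, a 2.7-fold lower number from compound 2 to compound 3 (0.43 log units; beyond the scatter). Neither step involves iodine, and neither moves a group from one ring carbon to another, so the record gives no direct guide for the present change. Both known steps on this ring are small, so no step beyond the scatter is expected in this assay for compound 4, in either direction: the expected step is a 1.2-fold lower number from compound 2 to compound 4 (0.06 log units; within the scatter). Compound 4 is therefore estimated at 30000 nM, with a range from 12000 nM to 80000 nM.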

Compound 4, half-maximal inhibitory concentration: 33400 nM
Compound 4: middle estimate off by 1.1-fold (0.05 log units), on the low side, and the stated range covers the measured number.
By their numbers in this assay, from the lowest: compounds 3, 1, 4 and 2 (each within the scatter of the next, the first and the last beyond it).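

In this assay, replacing 4-bromophenyl with 2-iodophenyl changes both the halogen and where it sits on the phenyl ring, yet the step stays within the scatter (a 1.0-fold lower number from compound 2 to compound 4 (0.02 log units; within the scatter)). Iodo in place of hydrogen on the same ring also stays within the scatter (a 1.4-fold higher number from compound 1 to compound 4 (0.15 log units; within the scatter)), so the plain phenyl of compound 1, the 4-bromophenyl of compound 2 and the 2-iodophenyl of compound 4 cannot be told apart in this assay, and these two halogens, at these two places, show no effect that can be read here. No measurement is at hand that could explain this result.

Since the halogen and its place change together between compound 2 and compound 4, the compounds shown cannot separate what each change contributes on its own. On these data alone, it also remains open whether an amine or a carboxylic acid on this phenyl ring would give a step beyond the scatter in this assay, as the methoxy group of compound 3 does when set against the bromo of compound 2.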